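A dichlorophenyl for a bromophenyl on a weakly cytotoxic chalcone

The source may report more compounds than this note shows. Statements on the series, on what has been measured and on what is new or still open speak of the compounds shown alone.

Compound 1 `CNC(=O)c1cc(Oc2ccc(C(=O)/C=C/c3ccc(Br)cc3)cc2)ccn1` was tested in a functional assay on A549 cells (Homo sapiens) for cytotoxicity, read by MTT assay, with a stated time of 72 h; a higher number here means a weaker inhibitor, a lower number a stronger inhibitor. In this assay compound 1 gives only a limit, > 50000 nM, and no single number. Within the values shown, compound 1 therefore stands at the edge of what the assay can report, as described by the limit of > 50000 nM in this assay, at which 1 of the 3 values shown sits. Two further members of the same series were also examined: compound 2 `CNC(=O)c1cc(Oc2ccc(/C=C/C(=O)c3ccc([N+](=O)[O-])cc3)cc2)ccn1`, for which this assay reports "not determined" (no result reported), and compound 3 `CNC(=O)c1cc(Oc2ccc(/C=C/C(=O)c3ccc(Cl)cc3)cc2)ccn1`, for which this assay likewise reports "not determined" (no result reported). Among the compounds with values here, no single-point step between measured compounds is available, so the account rests on compound 1 alone.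

Compound 4 `CNC(=O)c1cc(Oc2ccc(C(=O)/C=C/c3cccc(Cl)c3Cl)cc2)ccn1` has not yet been measured. It differs from compound 1 by 2,3-dichlorophenyl in place of 4-bromophenyl on a double-bonded chain carbon bound to a double-bonded chain carbon. Because compound 1 sits at the limit given by the limit of > 50000 nM in this assay, at which 1 of the 3 values shown sits, no change beyond the usual scatter is expected, and compound 4 is estimated to remain near that limit. The step from compound 1 to compound 4 in this assay is expected to be a number no higher from compound 1 to compound 4 (the limit leaves the size open). Compound 4 is thus estimated at 50000 nM, within a range from 15000 nM to 150000 nM.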

Compound 4, half-maximal inhibitory concentration: > 50000 nM
Compound 4 gave a limit, no number (the forecaster's own chance of this, stated with the estimate: 70%); the middle value sits exactly at the limit.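

No step can be read between compound 1 and compound 4 in this assay, since each gives only a limit and no number: the limit of > 50000 nM in this assay, at which 2 of the 4 values shown sit. Left open in this assay is how far either compound lies from that limit, and whether 2,3-dichlorophenyl and 4-bromophenyl differ at all.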